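Swapping an amine tail for a hydroxy group

The source may report more compounds than this note shows. Statements on the series, on what has been measured and on what is new or still open speak of the compounds shown alone.

Three close relatives of one chlorinated bicyclic core have been tested. In a functional assay on MDA-MB-231 cells (Homo sapiens) for cytotoxicity, read by MTT assay, with a stated time of 72 h, tested at 1 uM, in the absence of a further agent (on this read-out higher numbers stand for a weaker effect at the one concentration tested and lower numbers for a stronger effect), compound 1 `CC1(C)CC(NCCCCO)=Nc2ccc(Cl)cc21` gives 87.6%, compound 2 `CN(C)CCNC1=Nc2ccc(Cl)cc2C(C)(C)C1` gives 66.9%, and compound 3 `CCN(CC)CCCNC1=Nc2ccc(Cl)cc2C(C)(C)C1` gives 53.3%, the lowest of the three and thus the strongest effect among them. Compound 4 `CC1(C)CC(NCCCO)=Nc2ccc(Cl)cc21` differs from compound 3 by hydroxy in place of diethylamino on a saturated chain carbon, three bonds along the chain from an amine nitrogen. The most relevant measured step runs the other way: a number 34.3 percentage points lower from compound 1 to compound 3 (beyond the scatter), with a number 20.7 percentage points lower from compound 1 to compound 2 (beyond the scatter) pointing the same direction. Undoing that kind of change is therefore expected to bring the number back up by a large amount, roughly a number 31.7 percentage points higher from compound 3 to compound 4 (beyond the scatter). Compound 4 is estimated to show about 85%, within a range of 70% to 98%.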

Compound 4, a percentage reported as activity, at one concentration (the size of the read-out at that concentration, not a potency): 84.5%
Beside the measured number, compound 4's estimate is 0.5 percentage points above it, and the stated range covers the measured number.
By their numbers in this assay, from the lowest: compound 3; then compound 2; then compounds 4 and 1 (each within the scatter of the next).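

Compounds 3 and 4 share the same chain, so this is a clean exchange of the end group alone, and replacing diethylamino with hydroxy costs a large part of the effect (a number 31.2 percentage points higher from compound 3 to compound 4 (beyond the scatter)). The hydroxy compounds stay within the scatter of each other despite their different chains (a number 3.1 percentage points lower from compound 1 to compound 4 (within the scatter)), while compound 4 also sits clearly apart from the shorter dimethylamino compound (a number 17.6 percentage points higher from compound 2 to compound 4 (beyond the scatter)). No measurement at hand explains these steps. Going by these compounds, whether a plain amino group or a ring amine such as morpholine would behave like diethylamino remains open, as does the effect of a longer chain carrying diethylamino.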